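The compounds below may be only part of what the source reports. "The series", "measured", "known", "first", "only" and "open" are said of these compounds alone.

Measured compounds in an assay on HEK293 cells for inhibition of acid ceramidase (Homo sapiens), read by fluorescence, with stated times of 10 min and 3 h; a lower number here means a stronger inhibitor, a higher number a weaker inhibitor:
compound 1, `O=C(NCCCCc1ccccc1)n1c(=O)oc2cc(C3CCOCC3)ccc21`, gives 68 nM;
compound 2, `CN1CCN(c2ccc3c(c2)oc(=O)n3C(=O)NCCCCc2ccccc2)C(=O)C1`, gives 52 nM.

Compound 2 holds the lower of the two numbers, but the gap is small: a 1.3-fold lower number from compound 1 to compound 2 (0.12 log units; within the scatter) lies within the scatter of this assay, so neither compound can be called the stronger inhibitor. Both share the same core and the same side chain on the urea; they differ only in the saturated ring on the aromatic carbon.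

Compound 3, `CCN1CCN(c2ccc3c(c2)oc(=O)n3C(=O)NCCCCc2ccccc2)CC1`, changes that same ring once more: 4-ethylpiperazin-1-yl in place of 4-methyl-2-oxopiperazin-1-yl on an aromatic carbon. For the measured compounds named here, the only measured step that bears on this position, from compound 1 to compound 2, was within the scatter, and the data hold no other exchange at this carbon. Compound 3 is therefore expected to give 55 nM, with a range from 25 nM to 130 nM. The expected step from compound 2 is a 1.1-fold higher number from compound 2 to compound 3 (0.02 log units; within the scatter), no movement beyond the scatter.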

Compound 3, half-maximal inhibitory concentration: 56 nM
Estimate against measurement, compound 3: 1.0-fold (0.01 log units) below, and the stated range covers the measured number.
By their numbers in this assay, from the lowest: compounds 2, 3 and 1 (each within the scatter of the next).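

In this assay, 4-ethylpiperazin-1-yl in place of 4-methyl-2-oxopiperazin-1-yl gives a 1.1-fold higher number from compound 2 to compound 3 (0.03 log units; within the scatter), and 4-ethylpiperazin-1-yl in place of oxan-4-yl gives a 1.2-fold lower number from compound 1 to compound 3 (0.08 log units; within the scatter). The entering group holds no oxygen, whereas both groups it replaces do, so among these three six-membered rings neither the ring oxygen of compound 1 nor the carbonyl of compound 2 is needed to keep the number within the scatter. No measurement shown explains why the three numbers stay so close.

From the compounds shown here alone, what a carboxylic acid, an open-chain amine or a plain hydrogen would give on this aromatic carbon remains open. Going by these compounds, it is also open whether this tolerance would hold with a shorter chain in place of the side chain on the urea.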